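Exchanging one ring group on the core of compound 1

A few compounds are considered here, and "the series" means these few. Any claim that something is new, unique, unknown or untested is made for them only; others in the source may bear on it.

Going by the values given here, in an ADME assay on J774.A1 cells (Mus musculus) for cytotoxicity, read by MTT assay (on this read-out higher numbers stand for weaker inhibition and lower numbers for stronger inhibition), compound 1 `N#Cc1ccc(OCCCCCn2cc(/C=C3\NC(=O)NC3=O)c3ccccc32)cc1` gives 33 ug/mL, the only actual number available so far. Compound 2 `O=C1NC(=S)N/C1=C\c1cn(CCCCCOc2ccccc2)c2ccccc12` is recorded at > 100 ug/mL, which is a limit of the assay and not a number. Compound 3 `CSC1=N/C(=C\c2cn(CCCCCOc3ccc(C#N)cc3)c3ccccc23)C(=O)N1C` has yet to be measured. It departs from compound 1 in one place: a group of 10 heavy atoms (6 carbon, 2 nitrogen, 1 oxygen, 1 sulfur; one five-membered non-aromatic ring with 2 hetero atoms) in place of a group of 8 heavy atoms (4 carbon, 2 nitrogen, 2 oxygen; one five-membered non-aromatic ring with 2 hetero atoms), on an aromatic carbon. The exchange sits on an aromatic carbon of the shared core, and both groups contain a five-membered non-aromatic ring with 2 hetero atoms. Among the compounds with values here, no measured pair of compounds differs in only one place, so the data offer no step to lean on. In this assay, no shift beyond the usual scatter is therefore expected, and neither direction is favoured. The expected change is a 1.2-fold higher number from compound 1 to compound 3 (0.08 log units; within the scatter). For compound 3 the estimate is 40 ug/mL, with an expected range of 14 ug/mL to 100 ug/mL.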

Compound 3, half-maximal inhibitory concentration: > 100 ug/mL
Compound 3 was reported as a limit (the forecaster's own chance of this, stated with the estimate: 20%); middle value at least 2.5-fold (0.39 log units) away from the limit.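

In this assay, going by these compounds alone, the exchange on this aromatic carbon of the shared core gives an at least 3.0-fold higher number from compound 1 to compound 3 (0.48 log units; beyond the scatter), the first evidence that cytotoxicity in these cells responds to the group at this position, as the earlier compounds offered no pair differing in one place. Compound 3 stands at > 100 ug/mL, which is a limit of the assay and not a number. The full size of the step therefore cannot be read, because the values stop at that limit: the limit of > 100 ug/mL in this assay, at which 2 of the 3 values shown sit.

The single exchange adds sulfur and also replaces a group with 2 hydrogen-bond donors by one with 0, so the compounds shown do not tell which of these differences goes with the higher number. They also leave open how an amine or a carboxylic acid on this aromatic carbon would read in this assay.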